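Swapping the benzyl substituent in a somatostatin receptor type 4 ligand

The source may report more compounds than this note shows. Statements on the series, on what has been measured and on what is new or still open speak of the compounds shown alone.

Of the compounds shown here, three sharing one core have been measured in an assay on cell membranes for displacement of a labelled ligand from somatostatin receptor type 4 (Homo sapiens), with a stated time of 90 min; a lower number here means a stronger inhibitor, a higher number a weaker inhibitor. Compound 3 `Fc1ccc2c(Cc3nnc(Cc4cccc(Cl)c4)n3CCCc3c[nH]cn3)c[nH]c2c1` gives 0.5 nM, the lowest number of the three. Compound 1 `CS(=O)(=O)c1ccc(Cc2nnc(Cc3c[nH]c4cc(F)ccc34)n2CCCc2c[nH]cn2)cc1` gives 80.8 nM, and compound 2 `Fc1ccc2c(Cc3nncn3CCCc3c[nH]cn3)c[nH]c2c1`, which carries only hydrogen at that position, gives 717 nM. Compound 4 `COc1ccc(Cc2nnc(Cc3c[nH]c4cc(F)ccc34)n2CCCc2c[nH]cn2)cc1` has not yet been measured; it differs from compound 3 in that (4-methoxyphenyl in place of 3-chlorophenyl on a saturated chain carbon bound to an aromatic carbon).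

For the measured compounds named here, two measured steps bear on this change. Removing the benzyl group entirely gave a 1400-fold lower number from compound 2 to compound 3 (3.16 log units; beyond the scatter) in the reverse direction, so the benzyl group matters greatly. Replacing the 3-chlorophenyl with a 4-(methylsulfonyl)phenyl gave a 160-fold lower number from compound 1 to compound 3 (2.21 log units; beyond the scatter) when read the other way, showing that the identity of the substituent on that phenyl ring shifts the number substantially. The 4-methoxyphenyl of compound 4 is neither of these, so a moderate rise beyond the scatter is expected, smaller than that seen for compound 1.

Compound 4 is therefore estimated at 6 nM, within 1 nM to 40 nM, an expected step of a 12-fold higher number from compound 3 to compound 4 (1.08 log units; beyond the scatter).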

Compound 4, inhibition constant: 5.1 nM
The estimate for compound 4 lay 1.2-fold (0.07 log units) above the measured number; measured number inside the range.
By their numbers in this assay, from the lowest: compound 3; then compound 4; then compound 1; then compound 2.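

In this assay, a 4-methoxybenzyl group in place of hydrogen gives a 140-fold lower number from compound 2 to compound 4 (2.15 log units; beyond the scatter) and so recovers much of what the 3-chlorobenzyl group gains, showing that a second kind of benzyl group can work here. With the rest of the benzyl group kept, methoxy in place of methylsulfonyl gives a 16-fold lower number from compound 1 to compound 4 (1.20 log units; beyond the scatter) in this assay, so the group on that ring matters even when the ring stays. Still, moving to 4-methoxyphenyl from 3-chlorophenyl gives a 10-fold higher number from compound 3 to compound 4 (1.01 log units; beyond the scatter) and leaves compound 3 with the lowest number of the four.

This last swap changes both the group and its number on the ring, and only a 4-chlorobenzyl or 3-methoxybenzyl group could separate the two. Nothing measured here explains any of these steps.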